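This account rests on a few compounds, and the source may have more. Where it says the series, first, only, none or still open, it means among the compounds named here.

In a functional assay on SGC-7901 cells (Homo sapiens) for antiproliferative activity, read by sulforhodamine B assay, with a stated time of 72 h (on this read-out lower numbers stand for stronger inhibition and higher numbers for weaker inhibition), compound 1 `N#Cc1ccc(NC(=S)N/N=C/c2ccc3ccccc3n2)cc1` gives 23700 nM, compound 2 `S=C(N/N=C/c1ccc2ccccc2n1)Nc1cccc(Br)c1` gives 78600 nM and compound 3 `COc1cccc(NC(=S)N/N=C/c2ccc3ccccc3n2)c1` gives 79400 nM. Compound 3 shares the high end of these numbers with its bromo counterpart: methoxy in place of bromo gave a 1.0-fold higher number from compound 2 to compound 3 (0.00 log units; within the scatter). Leaving the 4-cyanophenyl group gave a 3.3-fold higher number from compound 1 to compound 2 (0.52 log units; beyond the scatter) and a 3.4-fold higher number from compound 1 to compound 3 (0.53 log units; beyond the scatter). Compound 4 `S=C(N/N=C/c1ccc2ccccc2n1)Nc1ccccc1Br` carries 2-bromophenyl in place of 3-methoxyphenyl on an amide-type nitrogen. Going by these compounds, the 2-bromophenyl group itself is untested, but compound 2, also a bromophenyl, stands at 78600 nM, so little movement is expected. The expected result in this assay is a 1.1-fold lower number from compound 3 to compound 4 (0.05 log units; within the scatter), no step beyond the scatter. The estimate for compound 4 is 70000 nM, with an expected range of 25000 nM to 180000 nM.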

Compound 4, half-maximal inhibitory concentration: > 100000 nM
Compound 4 ended at the assay's limit (the forecaster's own chance of this, stated with the estimate: 10%); at least 1.4-fold (0.15 log units) between middle value and limit.
By their numbers in this assay, from the lowest: compound 1; then compounds 2 and 3 (each within the scatter of the next). At a limit, above all of these: compound 4.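

In this assay compound 4 gives only a limit of the assay, not a number: the limit of > 100000 nM in this assay, at which 1 of the 4 values shown sits. On the amide-type nitrogen, 2-bromophenyl in place of 3-bromophenyl gives an at least 1.2-fold higher number from compound 2 to compound 4 (0.10 log units; that floor lies within the scatter), and in place of 3-methoxyphenyl it gives an at least 1.2-fold higher number from compound 3 to compound 4 (0.10 log units; that floor lies within the scatter), so neither floor separates these compounds. Only an at least 4.2-fold higher number from compound 1 to compound 4 (0.62 log units; beyond the scatter) clears the scatter, leaving 4-cyanophenyl alone at the low end of the four numbers.

Going by these compounds, how far the true value of compound 4 lies past the limit remains open. Also open, on these data alone, is how a 4-aminophenyl or 4-carboxyphenyl group on this nitrogen would compare with 4-cyanophenyl.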